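From dimethoxyphenyl to propyl on a shared core

The compounds below may be only part of what the source reports. "The series", "measured", "known", "first", "only" and "open" are said of these compounds alone.

Measured in a functional assay on A549 cells (Homo sapiens) for inhibition, read by MTT assay, with a stated time of 48 h; on this read-out higher numbers stand for weaker inhibition and lower numbers for stronger inhibition:
Compound 1 `COc1ccc(C(c2c[nH]c3ccc(Br)cc23)c2c[nH]c3ccc(Br)cc23)c(OC)c1`: 100000 nM
Compound 2 `COc1ccc(C(c2c[nH]c3ccc(Br)cc23)c2c[nH]c3ccc(Br)cc23)cc1OC`: 12000 nM
Compound 3 `COc1ccc(OC)c(C(c2c[nH]c3ccc(Br)cc23)c2c[nH]c3ccc(Br)cc23)c1`: 10000 nM

Compound 2 stands close to its nearest neighbour, with a 1.2-fold lower number from compound 2 to compound 3 (0.08 log units; within the scatter). Its distance from the furthest compound is larger, with an 8.3-fold lower number from compound 1 to compound 2 (0.92 log units; beyond the scatter).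

Compound 4 `CCCC(c1c[nH]c2ccc(Br)cc12)c1c[nH]c2ccc(Br)cc12` has not yet been measured. It carries propyl in place of 3,4-dimethoxyphenyl on a saturated chain carbon bound to two aromatic carbons. Among the compounds with values here, no measured step removes the dimethoxyphenyl group, so the data do not test this change directly. Within the data shown here, the only guide is how far the numbers moved when the methoxy groups alone were rearranged. Compound 1 shows modest movement, with a 10-fold lower number from compound 1 to compound 3 (1.00 log units; beyond the scatter), while compound 3 shows almost none from its neighbour, with a 1.2-fold lower number from compound 2 to compound 3 (0.08 log units; within the scatter). These steps suggest no clear direction, so only a small change is expected, with wide uncertainty. The step expected in this assay is a 1.3-fold higher number from compound 2 to compound 4 (0.10 log units; within the scatter). For compound 4 the estimated value is 15000 nM, with an expected range from 4000 nM to 60000 nM.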

Compound 4, half-maximal inhibitory concentration: 6500 nM
Compound 4: middle estimate off by 2.3-fold (0.36 log units), on the high side; the range from low to high includes it.
By their numbers in this assay, from the lowest: compounds 4, 3 and 2 (each within the scatter of the next); then compound 1.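

In this assay propyl on a saturated chain carbon bound to two aromatic carbons gives a 1.8-fold lower number from compound 2 to compound 4 (0.27 log units; within the scatter) and a 1.5-fold lower number from compound 3 to compound 4 (0.19 log units; within the scatter) so a chain with no ring and no hydrogen-bond acceptors stands level with the 3,4-dimethoxyphenyl and 2,5-dimethoxyphenyl groups at this place. The same exchange for 2,4-dimethoxyphenyl gives a 15-fold lower number from compound 1 to compound 4 (1.19 log units; beyond the scatter) and thus leaves the number of compound 1 apart from the other three, which shows that an aromatic ring at this place is not needed to reach the numbers of the 3,4-dimethoxyphenyl and 2,5-dimethoxyphenyl compounds. No evidence is available on what lies behind these steps. The compounds shown leave open whether a longer chain or an amine at this place would hold the number level with propyl. They also leave open whether a plain phenyl would stand with compound 1 or with the other three.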